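A few compounds are considered here, and "the series" means these few. Any claim that something is new, unique, unknown or untested is made for them only; others in the source may bear on it.

Measured in an ADME assay for permeability, using PAMPA, with a stated time of 30 min, at pH 7.4; a higher number here means that the compound crosses the layer faster, a lower number that the compound crosses the layer more slowly:
compound 1 `Fc1ccc(Oc2ccc3c(NCCCNCc4ccco4)ccnc3c2)cc1` gives 317 10^-6 cm/s
compound 2 `CC(C)CCc1ccc2c(NCCCNCc3ccco3)ccnc2c1` gives 23 10^-6 cm/s
compound 3 `COc1ccccc1Oc1ccc2c(NCCCNCc3ccco3)ccnc2c1` gives 317 10^-6 cm/s

Compound 3 stands level with compound 1, the two together the highest of the three: no change at the digits printed from compound 1 to compound 3 (within the scatter). The only large movement in the set comes from the alkyl analogue: a 14-fold higher number from compound 2 to compound 3 (1.14 log units; beyond the scatter), and likewise a 14-fold lower number from compound 1 to compound 2 (1.14 log units; beyond the scatter).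

Compound 4 `COc1ccc(Oc2ccc3c(NCCCNCc4ccco4)ccnc3c2)cc1` is not yet measured. Its change from compound 3 is 4-methoxyphenyl in place of 2-methoxyphenyl on an oxygen on an aromatic ring. The step that bears on it is the aryl swap on the same oxygen, no change at the digits printed from compound 1 to compound 3 (within the scatter), which stayed within the scatter; the large steps involve loss of the whole aryloxy group and do not apply. Accordingly no step beyond the scatter is expected: a 1.1-fold lower number from compound 3 to compound 4 (0.02 log units; within the scatter). Compound 4 is estimated at 300 10^-6 cm/s, range 150 10^-6 cm/s to 500 10^-6 cm/s.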

Compound 4, apparent permeability: 317 10^-6 cm/s
Beside the measured number, compound 4's estimate is 1.1-fold (0.02 log units) below it; measured number inside the range.
By their numbers in this assay, from the lowest: compound 2; then compounds 1, 3 and 4 (each within the scatter of the next).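

In this assay, 4-methoxyphenyl in place of 2-methoxyphenyl on the oxygen leaves the read-out unmoved (no change at the digits printed from compound 3 to compound 4 (within the scatter)), and methoxy in place of fluoro on an aromatic carbon does the same (no change at the digits printed from compound 1 to compound 4 (within the scatter)). The gap to the isopentyl analogue holds for this isomer too (a 14-fold higher number from compound 2 to compound 4 (1.14 log units; beyond the scatter)), so all three aryloxy compounds stand apart from compound 2. Nothing at hand explains these steps.

Open, as far as these compounds go, is whether an aryl ring carrying an amine or a carboxylic acid on the oxygen would keep this level. Also open, from the compounds shown here alone, is whether a benzyl group in place of isopentyl would stand with the aryloxy compounds or with compound 2.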